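This account rests on a few compounds, and the source may have more. Where it says the series, first, only, none or still open, it means among the compounds named here.

Compound 3 `CS(=O)(=O)Nc1ccc2c(c1)S(=O)(=O)N=C(C1=C(O)C3CCCC3N(CC3CCC3)C1=O)N2` carries a cyclobutylmethyl group on the amide-type ring nitrogen of the shared core. In an in vitro ADME assay on microsomes from liver (Homo sapiens) for metabolic stability (on this read-out higher numbers stand for a longer-lived compound and lower numbers for a shorter-lived compound), compound 3 gives 0.0667 h, the lowest of the three numbers. Compound 1 `CC(C)(C)CCN1C(=O)C(C2=NS(=O)(=O)c3cc(NS(C)(=O)=O)ccc3N2)=C(O)C2CCCCC21` gives 0.267 h in this assay, and compound 2 `CC(C)CCN1C(=O)C(C2=NS(=O)(=O)c3cc(NS(C)(=O)=O)ccc3N2)=C(O)[C@H]2CCC[C@H]21` gives 0.383 h; both gaps to compound 3 lie beyond the scatter. Compound 4 `CS(=O)(=O)Nc1ccc2c(c1)S(=O)(=O)N=C(C1=C(O)C3CCCC3N(Cc3ccccc3)C1=O)N2` differs from compound 3 by one change: phenyl in place of cyclobutyl on a saturated chain carbon bound to an amide-type nitrogen in a ring. Among the measured compounds shown here, no measured pair shows this change, so the direction cannot be read from the data. The step is estimated as a 1.3-fold higher number from compound 3 to compound 4 (0.13 log units; within the scatter), within the scatter. Compound 4 is therefore expected to give about 0.09 h in this assay, with a range from 0.04 h to 0.25 h.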

Compound 4, half-life: 0.833 h
The estimate for compound 4 lay 9.3-fold (0.97 log units) below the measured number; measured number above the stated range.
By their numbers in this assay, from the lowest: compound 3; then compounds 1 and 2 (each within the scatter of the next); then compound 4.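

On a saturated chain carbon bound to an amide-type nitrogen in a ring, phenyl in place of cyclobutyl gives a 12-fold higher number from compound 3 to compound 4 (1.10 log units; beyond the scatter) in this assay. Among the compounds shown here, this is the first step that can be read at this position, and it shows that the group here can shift the half-life by a large margin, which the earlier compounds, differing in more than one place, could not show. Nothing among the data explains the size of this step. The compounds shown leave open whether cyclohexyl, pyridyl or a longer chain ending in phenyl would keep the longer half-life at this place, and whether the same change would hold on the core of compound 1.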